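The source may hold more compounds than are shown below. What is called first, only, known or untested is meant among the compounds shown, and "the series" means these compounds.

The measured compounds:
compound 1, `Fc1ccccc1/C=C/c1ccccc1F`, in an assay on HepG2 cells for activation of nuclear factor erythroid 2-related factor 2 (Homo sapiens), read by a luciferase reporter, with a stated time of 5 h (on this read-out higher numbers stand for an effect only at larger amounts of compound and lower numbers for an effect already at smaller amounts), gives 4300 nM
compound 2, `Fc1ccc(/C=C/c2ccccc2F)cc1`, in this assay gives 3600 nM

Of these two numbers, compound 2 has the lower one, but its nearest neighbour is compound 1, and the margin between them lies within the scatter of repeated measurements, so the two cannot be set in order. Compound 3, `Fc1ccc(/C=C/c2ccccc2F)c(F)c1`, has not yet been measured in this assay. It differs from compound 2 in one place: fluoro in place of hydrogen on an aromatic carbon. Within the data shown here, no step between measured compounds is available that resembles this change, so the numbers so far give no direction for it. The step from compound 2 to compound 3 is therefore expected to stay within the scatter, and a 1.2-fold lower number from compound 2 to compound 3 (0.08 log units; within the scatter) is the size that the estimate means. Compound 3 is expected to give 3000 nM in this assay, within a range from 1200 nM to 7500 nM.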

Compound 3, half-maximal effective concentration: 9600 nM
Estimate against measurement, compound 3: 3.2-fold (0.51 log units) below; the measured number lies above the stated range.
By their numbers in this assay, from the lowest: compounds 2 and 1 (each within the scatter of the next); then compound 3.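

In this assay, among these compounds, fluoro in place of hydrogen on an aromatic carbon, ortho to a group of 9 heavy atoms and meta to a fluoro group, gives a 2.7-fold higher number from compound 2 to compound 3 (0.43 log units; beyond the scatter) and is the first change here to move the number beyond the scatter, towards an effect only at larger amounts of compound. The same change read against the other measured compound gives a 2.2-fold higher number from compound 1 to compound 3 (0.35 log units; beyond the scatter) as a second modest step, so compound 3 stands apart from compound 1 and compound 2, which cannot be set in order. No measurement at hand bears on what lies behind this step. Going by these compounds, what stays open is whether this position answers only to fluoro or equally to a larger group such as methoxy or to an amine. On these data alone, whether fluoro on another aromatic carbon of the shared core would give a step of the same direction also remains open.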